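Rearranging a Saturated Side Group and Expected Clearance

The compounds below may be only part of what the source reports. "The series", "measured", "known", "first", "only" and "open" are said of these compounds alone.

Measured compounds in an ADME assay on microsomes from liver (Homo sapiens) for metabolic stability, read by LC-MS; on this read-out lower numbers stand for slow clearance and higher numbers for fast clearance:
compound 1 `COc1ccc(NC(=O)c2ccc(-c3cnc(N4CCCN(C)CC4)nc3)cc2O)cc1Cl` gives 24 mL.min-1.g-1
compound 2 `CN1CCN(c2ncc(-c3ccc4c(NC5CCCCC5)ccnc4c3)cn2)CC1` gives 300 mL.min-1.g-1
compound 3 `CN1CCN(c2ncc(-c3ccc4c(N[C@@H]5CCCC[C@H]5O)ccnc4c3)cn2)CC1` gives 160 mL.min-1.g-1

Compound 3 lies within the scatter of compound 2 and well above compound 1, which sits at the slow end of this set. Going by the values given here, the only single-point step measured so far is a 1.9-fold lower number from compound 2 to compound 3 (0.27 log units; within the scatter). Compound 4 `CN1CCN(c2ncc(-c3ccc4c(NCC5CCOCC5)ccnc4c3)cn2)CC1` differs from compound 3 by (oxan-4-yl)methyl in place of 2-hydroxycyclohexyl on a nitrogen on an aromatic ring. Among the compounds with values here, that step is not the same as the measured one, but it stays on the same nitrogen of the shared core, and the one measured change there stayed within the scatter. Compound 4 is therefore expected to show a 1.3-fold higher number from compound 3 to compound 4 (0.10 log units; within the scatter) in this assay, and its estimated value is 200 mL.min-1.g-1 with a likely range from 90 mL.min-1.g-1 to 450 mL.min-1.g-1.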

Compound 4, intrinsic clearance in microsomes: 170 mL.min-1.g-1
Compound 4: middle estimate off by 1.2-fold (0.07 log units), on the high side; the range from low to high includes it.
By their numbers in this assay, from the lowest: compound 1; then compounds 3, 4 and 2 (each within the scatter of the next).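

In this assay, (oxan-4-yl)methyl in place of 2-hydroxycyclohexyl on this nitrogen stays within the scatter (a 1.1-fold higher number from compound 3 to compound 4 (0.03 log units; within the scatter)), and so does (oxan-4-yl)methyl in place of cyclohexyl (a 1.8-fold lower number from compound 2 to compound 4 (0.25 log units; within the scatter)). Rearranging the same atoms, from 1 hydrogen-bond donor to 0, therefore leaves the clearance number unmoved among these three compounds. Nothing measured here explains this result. Still open, as far as these compounds go, is whether a side group on this nitrogen carrying an amine or a carboxylic acid would move the number beyond the scatter.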